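Inverting one stereocentre of compound 2

This account rests on a few compounds, and the source may have more. Where it says the series, first, only, none or still open, it means among the compounds named here.

Compound 1 `Cc1cn([C@H]2C[C@H](CC3=CC(=O)C(=O)C=C3)[C@@H](CO[Si](C)(C)C(C)(C)C)O2)c(=O)[nH]c1=O`: no result reported
Compound 2 `COc1ccc(C2([C@H]3C[C@H](n4cc(C)c(=O)[nH]c4=O)O[C@@H]3CO[Si](C)(C)C(C)(C)C)SCCCS2)cc1OC`: 2290 nM

Two compounds of this series have so far been taken into a functional assay on PC-3 cells (Homo sapiens) for inhibition, read by sulforhodamine B assay, with a stated time of 48 h; on this read-out lower numbers stand for stronger inhibition of growth and higher numbers for weaker inhibition of growth. Within the data shown here, compound 1 has no result reported there, so compound 2 supplies the only number, 2290 nM, and it cannot yet be ranked against any other compound.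

Compound 3 `COc1ccc(C2([C@H]3C[C@@H](n4cc(C)c(=O)[nH]c4=O)O[C@@H]3CO[Si](C)(C)C(C)(C)C)SCCCS2)cc1OC` is still to be measured in this assay. Its relation to compound 2 is the two compounds have the same atoms and bonds and differ only in configuration as drawn: 1 of 3 stereo elements differ; a stereocentre at a saturated ring carbon is drawn R in compound 2 and S in compound 3. A stereocentre at a saturated ring carbon is drawn R in compound 2 and S in compound 3, while the atoms and bonds remain the same.

Among the measured compounds shown here, no measured pair shows what such an inversion does, so any forecast is uncertain and must start from compound 2 at 2290 nM. The expected result in this assay is no step beyond the usual scatter, with a slight lean towards weaker inhibition of growth. The estimated change is a 1.3-fold higher number from compound 2 to compound 3 (0.12 log units; within the scatter). For compound 3 the estimated value is 3000 nM, with an expected range from 1000 nM to 10000 nM.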

Compound 3, concentration for 50% growth inhibition: 3630 nM
The estimate for compound 3 lay 1.2-fold (0.08 log units) below the measured number; the range from low to high includes it.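

The drawn inversion at the saturated ring carbon, from R to S, comes to a 1.6-fold higher number from compound 2 to compound 3 (0.20 log units; within the scatter) in this assay, which gives the series its first measured pair for a change of this kind. On this read-out the two compounds cannot be told apart, so for this pair the configuration at this ring carbon shows no effect on growth inhibition that rises above the usual scatter. Nothing else enters this comparison, as the two structures hold no other difference: the fact that compounds 2 and 3 differ only in the configuration as drawn

This single pair cannot say whether the same inversion would also pass without a clear step in a compound carrying a free hydroxyl group in place of the silyl ether, or whether the result would hold in any other assay. The compounds shown also leave open what inverting either of the other two stereo elements would do to the number, so the finding is confined to this one position in this one pair.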